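The compounds below may be only part of what the source reports. "The series", "measured", "known", "first", "only" and "open" are said of these compounds alone.

Within the data shown here, compound 2, `COc1ccc(-c2cn(-c3cccc(C(=O)/C=C/c4cc(OC)c(OC)c(OC)c4)c3)c(=O)[nH]2)cc1`, gives the higher of the two numbers so far in a functional assay on MCF7 cells (Homo sapiens) for inhibition; on this read-out higher numbers stand for weaker inhibition of growth and lower numbers for stronger inhibition of growth: compound 2 reaches 440 nM. Among the measured compounds shown here, its only neighbour is compound 1, `COc1cc(/C=C/C(=O)c2cccc(-n3cc(-c4ccccc4)[nH]c3=O)c2)cc(OC)c1OC`, and compound 1 gives 310 nM in this assay; the step of a 1.4-fold higher number from compound 1 to compound 2 (0.15 log units; within the scatter), which is a methoxy in place of hydrogen on an aromatic carbon, lies within the scatter, so the two compounds cannot be ranked against each other.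

Compound 3, `COc1cc(/C=C/C(=O)c2cccc(-n3cc(-c4cc(OC)c(OC)c(OC)c4)[nH]c3=O)c2)cc(OC)c1OC`, carries a further change on the same side of the shared core: 3,4,5-trimethoxyphenyl in place of 4-methoxyphenyl on an aromatic carbon. For the measured compounds named here, the only step that bears on it is the one from compound 1 to compound 2, where a first methoxy on that ring left the number essentially unchanged. Going by the values given here, two more methoxy groups on the same ring have no measured precedent here, so the expectation rests on that one step alone and calls for no movement beyond the scatter in this assay, with a wide margin for surprise.

Compound 3 is therefore expected to give about 500 nM, between 200 nM and 1300 nM, an estimated step of a 1.1-fold higher number from compound 2 to compound 3 (0.06 log units; within the scatter) from compound 2.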

Compound 3, concentration for 50% growth inhibition: 470 nM
The estimate for compound 3 lay 1.1-fold (0.03 log units) above the measured number, within the range that was stated.
By their numbers in this assay, from the lowest: compounds 1, 2 and 3 (each within the scatter of the next).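

In this assay the swap of 4-methoxyphenyl for 3,4,5-trimethoxyphenyl gives a 1.1-fold higher number from compound 2 to compound 3 (0.03 log units; within the scatter) and so stays inside the normal spread of repeat measurements. Counted from the unsubstituted phenyl, the full change gives a 1.5-fold higher number from compound 1 to compound 3 (0.18 log units; within the scatter) and stays inside that spread as well, so the earlier finding for a single methoxy group now extends to three methoxy groups on this ring. This position, on an aromatic carbon of a five-membered aromatic ring with 2 nitrogen, therefore accepts a group that grows from 8 to 12 heavy atoms and from 1 to 3 hydrogen-bond acceptors without separating the compounds on this read-out, and no supporting measurement is available to explain this result.

From the compounds shown here alone, all three compounds carry a phenyl ring here, with only hydrogen or methoxy groups on it, so it remains open whether the ring itself matters or a simple methyl group could take its place. Also open, going by these compounds, is whether an amine or a carboxylic acid on this ring would produce a step larger than the scatter, which would show that the read-out responds to changes here at all.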